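The source may report more compounds than this note shows. Statements on the series, on what has been measured and on what is new or still open speak of the compounds shown alone.

Measured compounds:
Compound 1 `O=C(Nc1cccc(/C=C/C(=O)c2nc3ccccc3[nH]2)c1)c1ccccc1`: 8340 nM in a functional assay on 143B cells (Homo sapiens) for antiproliferative activity, read by MTT assay, with a stated time of 48 h; on this read-out higher numbers stand for weaker inhibition and lower numbers for stronger inhibition
Compound 2 `O=C(Nc1cccc(/C=C/C(=O)c2nc3ccccc3[nH]2)c1)c1ccc(Cl)cc1`: 7440 nM in this assay

Compound 2 gives the lowest of the two numbers shown, but a 1.1-fold lower number from compound 1 to compound 2 (0.05 log units; within the scatter) falls within the scatter, so the two compounds stand level on this read-out. Compound 3 `O=C(Nc1cccc(/C=C/C(=O)c2nc3ccccc3[nH]2)c1)c1ccc(Br)cc1` differs from compound 2 by bromo in place of chloro on an aromatic carbon. Within the data shown here, only the step from compound 1 to compound 2 bears on this change, and it was small, so a step of no size beyond the scatter is expected in this assay. Compound 3 is therefore estimated at 6500 nM (range 3000 nM to 14000 nM), which means an expected step of a 1.1-fold lower number from compound 2 to compound 3 (0.06 log units; within the scatter).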

Compound 3, half-maximal inhibitory concentration: 7310 nM
For compound 3 the middle estimate is 1.1-fold (0.05 log units) below the measured one; the range from low to high includes it.
By their numbers in this assay, from the lowest: compounds 3, 2 and 1 (each within the scatter of the next).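

Bromo in place of chloro, on the aromatic carbon para to a large group, gives a 1.0-fold lower number from compound 2 to compound 3 (0.01 log units; within the scatter) in this assay, and bromo in place of hydrogen gives a 1.1-fold lower number from compound 1 to compound 3 (0.06 log units; within the scatter). A second halogen at this position thus also leaves the read-out level with hydrogen, so the flat result is not confined to chloro. Going by these compounds, whether an amine or a carboxylic acid at this position would move the number stays open. So does the effect of a methoxy group elsewhere on this ring, and nothing at hand gives a reason for the level result.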